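The source may hold more compounds than are shown below. What is called first, only, known or untested is meant among the compounds shown, and "the series" means these compounds.

Compound 3 `CCn1c(SCC(=O)Nc2ccc(/C(C)=N/O)cc2)nnc1-c1ccc(OC)c(OC)c1` gives the highest of the three numbers measured in a functional assay on the whole organism (strain albino) for inhibition, with Rattus norvegicus as the target, read by paw edema, with stated times of 30 min and 2 h, at a dose of 0.28 mmol/kg by the oral route (a higher number here means more inhibition at the dose given (going by the name of the read-out), a lower number less inhibition), namely 65%; compound 1 `C=CCn1c(SCC(=O)Nc2ccc(/C(C)=N/O)cc2)nnc1-c1ccccc1` with 63% lies within the scatter of it, while compound 2 `C/C(=N\O)c1ccc(NC(=O)CSc2nnc(-c3ccccc3)n2-c2ccccc2)cc1` with 52% lies beyond it. Within the data shown here, the one measured step, a number 11 percentage points lower from compound 1 to compound 2 (beyond the scatter), concerns a change on the ring nitrogen and not the aromatic carbon, so it does not bear directly on the change to compound 4 `CCn1c(SCC(=O)Nc2ccc(/C(C)=N/O)cc2)nnc1-c1ccccc1`, which is phenyl in place of 3,4-dimethoxyphenyl on an aromatic carbon. Compound 1 shares the plain phenyl on that carbon and its value sits close to that of compound 3, so no step beyond the scatter is expected, with a number 5 percentage points lower from compound 3 to compound 4 (within the scatter) estimated. Compound 4 is therefore expected to give about 60%, between 48% and 72%.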

Compound 4, a percentage reported as inhibition, in the whole organism at one dose (the size of the read-out at that dose, not a potency): 57%
For compound 4 the middle estimate is 3 percentage points above the measured one; measured number inside the range.
By their numbers in this assay, from the lowest: compounds 2, 4, 1 and 3 (each within the scatter of the next, the first and the last beyond it).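

Phenyl in place of 3,4-dimethoxyphenyl on this aromatic carbon gives a number 8 percentage points lower from compound 3 to compound 4 (within the scatter) in this assay, so the read-out does not separate these two groups at this position. On the aromatic nitrogen, ethyl in place of phenyl gives a number 5 percentage points higher from compound 2 to compound 4 (within the scatter) and methyl in place of vinyl on the chain gives a number 6 percentage points lower from compound 1 to compound 4 (within the scatter); compound 4 thus lies within the scatter of both neighbours, although compound 1 and compound 2 stand apart. No available evidence accounts for these numbers. Going by these compounds, whether an amine or a carboxylic acid on that phenyl, or a longer chain on the ring nitrogen, would shift the inhibition beyond the scatter remains open.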